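The source may report more compounds than this note shows. Statements on the series, on what has been measured and on what is new or still open speak of the compounds shown alone.

Of the compounds shown here, three sharing one core have been measured in an ADME assay on SK-OV-3 cells (Homo sapiens) for cytotoxicity, read by sulforhodamine B assay, with a stated time of 48 h, tested at 10 uM; a lower number here means less inhibition, a higher number more inhibition at the concentration tested (going by the name of the read-out). Compound 1 `CCCCCCCc1cn(C(c2ccccc2)c2cc3cc(Br)ccc3nc2OC)nn1` gives 10.5%. Compound 2 `CCCCCCCCc1cn(C(c2ccccc2)c2cc3cc(Br)ccc3nc2OC)nn1` gives 2.06%, and compound 3 `CCCc1cn(C(c2ccccc2)c2cc3cc(Br)ccc3nc2OC)nn1` gives 11.2%, the highest of the three numbers, though its gaps to both others lie within the scatter. Compound 4 `COc1nc2ccc(Br)cc2cc1C(c1ccccc1)n1cc(CO)nn1` differs from compound 3 by hydroxy in place of ethyl on a saturated chain carbon bound to an aromatic carbon. The measured steps that bear on this are the ones that shorten the same chain: a number 0.7 percentage points higher from compound 1 to compound 3 (within the scatter) and a number 9.1 percentage points higher from compound 2 to compound 3 (within the scatter), both within the scatter. Compound 4 shortens that chain further and adds a hydroxy group, so no step beyond the scatter is expected. For compound 4 the expected value is 10%, with a range from 0% to 22%, meaning an expected step of a number 1.2 percentage points lower from compound 3 to compound 4 (within the scatter).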

Compound 4, a percentage reported as inhibition, at one concentration (the size of the read-out at that concentration, not a potency): 3.23%
Compound 4: middle estimate off by 6.8 percentage points, on the high side, and the stated range covers the measured number.
By their numbers in this assay, from the lowest: compounds 2, 4, 1 and 3 (each within the scatter of the next).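

Swapping propyl for hydroxymethyl, which brings in a hydrogen-bond donor and acceptor, gives in this assay a number 8 percentage points lower from compound 3 to compound 4 (within the scatter) and, set against the longer chains, a number 7.3 percentage points lower from compound 1 to compound 4 (within the scatter) and a number 1.2 percentage points higher from compound 2 to compound 4 (within the scatter). So this position now holds a group carrying hydroxy as well as plain alkyl chains, with no step beyond the scatter among the compounds shown. No measurement is available that would explain these numbers. As far as these compounds go, whether an amine, a carboxylic acid or a methyl ether here would give a step beyond the scatter stays open.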